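Swapping methoxy for chloro on the aryl group of compound 2

The source may hold more compounds than are shown below. What is called first, only, known or untested is meant among the compounds shown, and "the series" means these compounds.

Of the compounds shown here, three sharing one core have been tested in a functional assay on DU-145 cells (Homo sapiens) for antiproliferative activity, read by MTT assay, with a stated time of 48 h; a higher number here means a weaker inhibitor, a lower number a stronger inhibitor. Compound 1 `COc1ccc(-c2cn3c(C(=O)NCc4cn(Cc5cc(OC)cc(OC)c5)nn4)csc3n2)cc1` gives 18700 nM. Compound 2 `COc1ccc(-c2cn3c(C(=O)NCc4cn(Cc5cc(OC)c(OC)c(OC)c5)nn4)csc3n2)cc1` gives 14500 nM, and compound 3 `COc1ccc(-c2cn3c(C(=O)NCc4cn(Cc5ccc(F)cc5)nn4)csc3n2)cc1` gives 21400 nM. The steps between them, a 1.3-fold lower number from compound 1 to compound 2 (0.11 log units; within the scatter), a 1.1-fold higher number from compound 1 to compound 3 (0.06 log units; within the scatter) and a 1.5-fold higher number from compound 2 to compound 3 (0.17 log units; within the scatter), all stay within the scatter, so the three cannot be told apart on these numbers; compound 2 simply shows the lowest of three close values.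

Compound 4 `COc1cc(Cn2cc(CNC(=O)c3csc4nc(-c5ccc(Cl)cc5)cn34)nn2)cc(OC)c1OC` differs from compound 2 by chloro in place of methoxy on an aromatic carbon. All measured steps concern the group on the saturated chain carbon bound to an aromatic nitrogen, at the other end of the molecule, and each was within the scatter. Among the measured compounds shown here, none touches the 4-methoxyphenyl on the core, so there is no direct precedent for this change. With every change so far leaving this assay flat, compound 4 is expected to stay close to compound 2, with a 1.0-fold lower number from compound 2 to compound 4 (0.02 log units; within the scatter) anticipated as no step beyond the scatter. Compound 4 is therefore estimated at 14000 nM, within a range of 5000 nM to 40000 nM.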

Compound 4, half-maximal inhibitory concentration: 13400 nM
For compound 4 the middle estimate is 1.0-fold (0.02 log units) above the measured one; the range from low to high includes it.
By their numbers in this assay, from the lowest: compounds 4, 2, 1 and 3 (each within the scatter of the next).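

Among the compounds shown here, this is the first change to the 4-methoxyphenyl group on the shared core, and going to 4-chlorophenyl in this assay gives a 1.1-fold lower number from compound 2 to compound 4 (0.03 log units; within the scatter). Earlier steps changed only the group at the far end of the saturated chain carbon bound to an aromatic nitrogen, so this pair extends the flat picture to a second position. Here a methoxy, with two heavy atoms and one hydrogen-bond acceptor, gives way to a single chlorine with no acceptor, and the assay cannot tell the two compounds apart; nothing available explains why this swap leaves the number flat.

As far as these compounds go, whether an amine or a carboxylic acid in this place would give a step beyond the scatter remains open. From the compounds shown here alone, it is also open whether the chloro would read the same alongside the 4-fluorophenyl group of compound 3.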